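Swapping the amide nitrogen substituent on a fluorinated core

The compounds below may be only part of what the source reports. "The series", "measured", "known", "first", "only" and "open" are said of these compounds alone.

Of the compounds shown here, three sharing a related core have been tested in a functional assay on the whole organism with Rattus norvegicus as the target, at a dose of 20 mg/kg by the oral route; a higher number here means more inhibition at the dose given (going by the name of the read-out), a lower number less inhibition. Compound 1 `NC(=O)/C=C1\CCc2cc(Cl)ccc21` gives 29% in this assay. Compound 2 `O=C(/C=C1\CCc2ccc(F)cc21)NCCO` gives 78% in this assay, and compound 3 `O=C(/C=C1\CCc2c(F)cc(F)cc21)NC1CC1` gives 28% in this assay. Compound 2 therefore stands highest of the three numbers: compound 1 sits nearest, a number well beyond the usual scatter below it, and compound 3 sits furthest, also beyond the scatter.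

Compound 4 `O=C(/C=C1\CCc2ccc(F)cc21)N1CCC1` has not yet been measured in this assay. Compared with compound 2, it carries the change (azetidin-1-yl in place of (2-hydroxyethyl)amino on a carbonyl carbon). Among the measured compounds shown here, neither this change nor any single-point step between two measured compounds has been seen, so no measured step guides the expectation directly.

The step from compound 2 to compound 4 in this assay is expected to be a drop beyond the scatter, a number 33 percentage points lower from compound 2 to compound 4 (beyond the scatter), since the two measured neighbours of compound 2, compound 1 at 29% and compound 3 at 28%, both sit far lower. For compound 4 the estimate in this assay is 45%, with a range from 15% to 75%.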

Compound 4, a percentage reported as inhibition, in the whole organism at one dose (the size of the read-out at that dose, not a potency): 0%
The estimate for compound 4 lay 45 percentage points above the measured number, and the stated range ends above it.
By their numbers in this assay, from the lowest: compound 4; then compounds 3 and 1 (each within the scatter of the next); then compound 2.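

Among the compounds shown here, this is the first step that changes only the group on the carbonyl carbon while the shared core stays the same, and in this assay it reads a number 78 percentage points lower from compound 2 to compound 4 (beyond the scatter). The leaving (2-hydroxyethyl)amino group and the entering azetidin-1-yl group both hold 4 heavy atoms, so at this position a matching heavy-atom count does not preserve the read-out at this dose; the two groups differ in having no ring against a four-membered ring, and in 2 hydrogen-bond donors and 1 acceptor against none. Nothing measured here says which of these differences accounts for the loss.

The compounds shown leave open whether the hydroxyl group or the amide hydrogen matters more, a question that an ethylamino group, a 2-methoxyethylamino group or a 3-hydroxyazetidin-1-yl group on the same carbonyl carbon could help to separate. Compound 1 and compound 3 differ from compound 2 in more than one place, so they cannot settle this question.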